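The source may hold more compounds than are shown below. What is called first, only, known or untested is meant among the compounds shown, and "the series" means these compounds.

In a functional assay on MCF7 cells (Homo sapiens) for antiproliferative activity, read by MTT assay, with a stated time of 48 h (a higher number here means a weaker inhibitor, a lower number a stronger inhibitor), compound 1 (`Cc1cc2nc(NC(c3cn(-c4ccccc4)nc3-c3ccc([N+](=O)[O-])cc3)c3c(O)ccc4ccccc34)sc2cc1C`) gives 41100 nM and compound 3 (`Oc1ccc2ccccc2c1C(Nc1nc2ccccc2s1)c1cn(-c2ccccc2)nc1-c1cccc(Cl)c1`) gives 20700 nM while compound 2 (`O=[N+]([O-])c1ccc(-c2nn(-c3ccccc3)cc2C(Nc2nc3ccccc3s2)c2c(O)ccc3ccccc23)cc1`) gives 14700 nM at the low end of the three and within the scatter of compound 3. Compound 4 (`COc1ccc2nc(NC(c3cn(-c4ccccc4)nc3-c3ccc([N+](=O)[O-])cc3)c3c(O)ccc4ccccc34)sc2c1`) has methoxy in place of hydrogen on an aromatic carbon of compound 2 (methoxy in place of hydrogen on an aromatic carbon), giving 6-methoxy-1,3-benzothiazol-2-yl. The nearest evidence is a 2.8-fold lower number from compound 1 to compound 2 (0.45 log units; beyond the scatter) for 1,3-benzothiazol-2-yl in place of 5,6-dimethyl-1,3-benzothiazol-2-yl. The step of a 1.4-fold higher number from compound 2 to compound 3 (0.15 log units; within the scatter) lies in another group and bears little on this change. A smaller rise in the number, possibly within the scatter, is therefore expected in this assay with an estimated 1.4-fold higher number from compound 2 to compound 4 (0.15 log units; within the scatter) as its size. Compound 4 is estimated at 21000 nM with an expected range of 8000 nM to 50000 nM overall.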

Compound 4, half-maximal inhibitory concentration: 13300 nM
Compound 4: the middle estimate sits 1.6-fold (0.20 log units) above what was measured; the measured number falls inside the stated range.
By their numbers in this assay, from the lowest: compounds 4, 2, 3 and 1 (each within the scatter of the next, the first and the last beyond it).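

In this assay, methoxy on the 1,3-benzothiazol-2-yl group makes little measurable difference, with a 1.1-fold lower number from compound 2 to compound 4 (0.04 log units; within the scatter). The 6-methoxy-1,3-benzothiazol-2-yl group also stands apart from the 5,6-dimethyl-1,3-benzothiazol-2-yl group of compound 1, with a 3.1-fold lower number from compound 1 to compound 4 (0.49 log units; beyond the scatter), so a substituent at this place does not by itself go with the higher number of compound 1. Nothing available explains either step. On these data alone, whether an amine, a carboxylic acid or a longer chain such as butoxy at this place would also stay within the scatter remains open.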